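This account rests on a few compounds, and the source may have more. Where it says the series, first, only, none or still open, it means among the compounds named here.

Working notes on the series. Compound 1 `CN1CCN(CCCCOc2c(OCc3cccs3)cc(O)c3c(=O)cc(-c4ccccc4)oc23)CC1` carries a thiophen-2-yl group on the saturated chain carbon bound to an oxygen on the aromatic ring; in a functional assay on MCF7 cells (Homo sapiens) for cytotoxicity, read by MTT assay, with a stated time of 72 h (on this read-out lower numbers stand for stronger inhibition and higher numbers for weaker inhibition), compound 1 gives 3180 nM. Among the compounds with values here, compound 2 `CN1CCN(CCCCOc2c(OCc3nc4ccccc4o3)cc(O)c3c(=O)cc(-c4ccccc4)oc23)CC1` has a 1,3-benzoxazol-2-yl group at that place, and in this assay compound 2 gives 4980 nM, the highest of the two numbers so far, with compound 1 nearest to it. Within the data shown here, the only step measured, a 1.6-fold higher number from compound 1 to compound 2 (0.19 log units; within the scatter), is the swap of ring at this carbon.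

Compound 3 `CN1CCN(CCCCOc2c(OCc3nc4ccccc4s3)cc(O)c3c(=O)cc(-c4ccccc4)oc23)CC1` is the next member. The change is 1,3-benzothiazol-2-yl in place of 1,3-benzoxazol-2-yl on a saturated chain carbon bound to an oxygen on an aromatic ring. Among the measured compounds shown here, the one measured step at this position, a 1.6-fold higher number from compound 1 to compound 2 (0.19 log units; within the scatter), stayed inside the scatter, and no other step bears on the exchange of oxygen for sulfur in the fused ring. The expectation is therefore no step beyond the scatter, a 1.1-fold lower number from compound 2 to compound 3 (0.04 log units; within the scatter). Compound 3 is estimated at 4500 nM in this assay, with a range from 2000 nM to 10000 nM.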

Compound 3, half-maximal inhibitory concentration: 4850 nM
Estimate against measurement, compound 3: 1.1-fold (0.03 log units) below, and the stated range covers the measured number.
By their numbers in this assay, from the lowest: compounds 1, 3 and 2 (each within the scatter of the next).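

The exchange of oxygen for sulfur inside the fused ring gives a 1.0-fold lower number from compound 2 to compound 3 (0.01 log units; within the scatter) in this assay, so this change, unlike the earlier swap of one ring for another, keeps the ring size and the counted hydrogen-bond acceptors and still shows no step beyond the scatter. With a 1.5-fold higher number from compound 1 to compound 3 (0.18 log units; within the scatter) also within the scatter, the thiophen-2-yl, 1,3-benzoxazol-2-yl and 1,3-benzothiazol-2-yl groups on the saturated chain carbon bound to an oxygen on an aromatic ring are not told apart by these numbers. No supporting data bear on this result.

Going by these compounds, whether a group of another kind at this place, such as a carboxylic acid or a primary amine, would give a step beyond the scatter remains open. On these data alone, a longer chain between the carbon and its ring is equally open.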